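From compound 2 to compound 4: an untested benzyl

The compounds below may be only part of what the source reports. "The series", "measured", "known", "first", "only" and "open" are said of these compounds alone.

The three measured compounds share one core and differ only in the group on an aromatic carbon next to the ring nitrogen. Compound 2 `CC(C(=O)NCc1ccc(C(F)(F)F)nc1-c1ccc(F)c(Cl)c1)c1ccc(NS(C)(=O)=O)c(F)c1` carries 3-chloro-4-fluorophenyl there, and in an assay on CHO cells for antagonist activity at transient receptor potential cation channel subfamily V member 1 (Homo sapiens), read by FLIPR (on this read-out lower numbers stand for stronger inhibition and higher numbers for weaker inhibition), compound 2 gives 0.2 nM, the lowest of the three numbers. Compound 3 `CC(C(=O)NCc1ccc(C(F)(F)F)nc1-c1ccoc1)c1ccc(NS(C)(=O)=O)c(F)c1` carries furan-3-yl and gives 1.4 nM; compound 1 `CC(C(=O)NCc1ccc(C(F)(F)F)nc1-c1ccccc1F)c1ccc(NS(C)(=O)=O)c(F)c1` carries 2-fluorophenyl and gives 63.3 nM. The measured steps are a 7.0-fold higher number from compound 2 to compound 3 (0.85 log units; beyond the scatter) and a 320-fold lower number from compound 1 to compound 2 (2.50 log units; beyond the scatter), so the identity of this group moves the number a great deal.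

Going by the values given here, compound 4 `CC(C(=O)NCc1ccc(C(F)(F)F)nc1Cc1ccccc1)c1ccc(NS(C)(=O)=O)c(F)c1` has not yet been measured. benzyl in place of 3-chloro-4-fluorophenyl on an aromatic carbon No measured step places a benzyl at this position, so the comparison rests only on the wide spread seen among the three aryl groups. Given that spread, a rise in the number beyond the scatter is expected, amounting to a 75-fold higher number from compound 2 to compound 4 (1.88 log units; beyond the scatter). For compound 4 the estimate is 15 nM, with an expected range from 1.5 nM to 150 nM.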

Compound 4, inhibition constant: 141 nM
Compound 4: the middle estimate sits 9.4-fold (0.97 log units) below what was measured, within the range that was stated.
By their numbers in this assay, from the lowest: compound 2; then compound 3; then compound 1; then compound 4.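

With benzyl at this position, compound 4 has the highest number of the four in this assay: the change gives a 710-fold higher number from compound 2 to compound 4 (2.85 log units; beyond the scatter) and a 100-fold higher number from compound 3 to compound 4 (2.00 log units; beyond the scatter) and even a 2.2-fold higher number from compound 1 to compound 4 (0.35 log units; beyond the scatter). A six-membered aromatic ring of carbon only is present in both the group that leaves and the group that enters, so that ring alone does not secure a low number here. No measurement shown gives a cause for these steps.

Still open, from the compounds shown here alone, is whether the rise goes with the added carbon of benzyl or with the absence of chlorine and fluorine, which a 3-chloro-4-fluorobenzyl group would help to separate. Going by these compounds, how an amine or a longer chain such as phenethyl would behave at this position is equally open.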